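From 3-fluorobenzyl to 4-chlorobenzyl on the shared core

A few compounds are considered here, and "the series" means these few. Any claim that something is new, unique, unknown or untested is made for them only; others in the source may bear on it.

compound 1 (`N#C/C(=C\c1ccccc1OS(=O)(=O)c1ccc([N+](=O)[O-])cc1)C(=O)Nc1nnc(-c2cccs2)s1`): 33%
compound 2 (`COc1ccc(Cc2nnc(NC(=O)/C(C#N)=C/c3ccccc3OS(=O)(=O)c3ccc([N+](=O)[O-])cc3)s2)cc1`): 17%
compound 3 (`N#C/C(=C\c1ccccc1OS(=O)(=O)c1ccc([N+](=O)[O-])cc1)C(=O)Nc1nnc(Cc2cccc(F)c2)s1`): "not toxic" (no number reported)

These values come from an ADME assay on HEK-293T cells (Homo sapiens) for inhibition, read by CCK-8 assay, with a stated time of 48 h, tested at 20 uM; a lower number here means less inhibition of growth, a higher number more inhibition of growth at the concentration tested. Compound 3 has no single number there, only the verdict "not toxic" (no number reported). Compound 4 (`N#C/C(=C\c1ccccc1OS(=O)(=O)c1ccc([N+](=O)[O-])cc1)C(=O)Nc1nnc(Cc2ccc(Cl)cc2)s1`) differs from it as follows: 4-chlorophenyl in place of 3-fluorophenyl on a saturated chain carbon bound to an aromatic carbon. Among the compounds with values here, no measured step covers this exchange. Within the data shown here, the only step available, a number 16 percentage points lower from compound 1 to compound 2 (beyond the scatter), involves different groups at a different place, so it bears only loosely on the change. With no number for compound 3, no step size can be calculated, and no change beyond the scatter is expected. Compound 2, which carries a 4-methoxybenzyl group, gives 17% and serves as the closest numerical guide. Compound 4 is expected to show 15%, with an estimated range from 3% to 35%.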

Compound 4, percent growth inhibition at one concentration: 19%
Compound 4: the middle estimate sits 4 percentage points below what was measured; the range from low to high includes it.
By their numbers in this assay, from the lowest: compounds 2 and 4 (each within the scatter of the next); then compound 1.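

In this assay, the 4-chlorobenzyl and 4-methoxybenzyl groups on the shared core read alike (a number 2 percentage points higher from compound 2 to compound 4 (within the scatter)). Compound 4 also gives a second benzyl example set apart from the thiophen-2-yl group of compound 1 (a number 14 percentage points lower from compound 1 to compound 4 (beyond the scatter)), so among the compounds with numbers, both benzyl compounds share this separation. Nothing available explains these differences.

Compound 3 has only a verdict, so steps to it cannot be read. Still open, from the compounds shown here alone, is how a 4-aminobenzyl group, a 4-carboxybenzyl group or a longer chain would read here.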